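Compound 4: chloro in place of ethyl

A few compounds are considered here, and "the series" means these few. Any claim that something is new, unique, unknown or untested is made for them only; others in the source may bear on it.

Within the data shown here, in a functional assay on SMMC-7721 cells (Homo sapiens) for inhibition, read by CCK-8 assay, with a stated time of 72 h, tested at 8 uM (a higher number here means more inhibition of growth at the concentration tested, a lower number less inhibition of growth), compound 2 (`CCc1ccc(SCc2ccc(C(=O)Nc3ccccc3N)cc2)cc1`) gives 82.9% and stands highest of the three numbers so far. Compound 1 (`COc1ccc(SCc2ccc(/C=C/C(=O)Nc3ccccc3N)cc2)cc1OC`) gives 44.6% on this read-out, and compound 3 (`Nc1ccccc1NC(=O)/C=C/c1ccc(CSc2cccc3ccccc23)cc1`) gives 18.3% on it.

Compound 4 (`Nc1ccccc1NC(=O)c1ccc(CSc2ccc(Cl)cc2)cc1`) is not yet measured. Its difference from compound 2 (chloro in place of ethyl on an aromatic carbon) is chloro in place of ethyl on an aromatic carbon, para to a large group.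

Among the measured compounds shown here, only one measured step bears on this: a number 26.3 percentage points lower from compound 1 to compound 3 (beyond the scatter) for naphthalen-1-yl in place of 3,4-dimethoxyphenyl on a sulfur. It shows that the group on sulfur can move the number, but it replaces a whole ring group on the core of compound 1, not a single substituent on the core of compound 2. For the measured compounds named here, no measured step compares chloro with ethyl, so the guide is weak.

No step beyond the scatter is expected, and the estimated step is a number 6.9 percentage points lower from compound 2 to compound 4 (within the scatter) in this assay for now. For compound 4 the expected value is 76% with a range from 55% to 92% as the estimate.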

Compound 4, percent growth inhibition at one concentration: 16.5%
Beside the measured number, compound 4's estimate is 59.5 percentage points above it, outside the stated range (below it).
By their numbers in this assay, from the lowest: compounds 4 and 3 (each within the scatter of the next); then compound 1; then compound 2.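

In this assay the core of compound 2 shows a number 66.4 percentage points lower from compound 2 to compound 4 (beyond the scatter) for a single substituent, para to a large group, so this one place can carry a large step. The earlier step, a number 26.3 percentage points lower from compound 1 to compound 3 (beyond the scatter) on the core of compound 1, replaced a whole ring group, whereas the change from 4-ethylphenyl to 4-chlorophenyl swaps two heavy atoms for one and leaves the counted donors and acceptors at zero. No measured property of either group bears on this result.

Open, as far as these compounds go, is how methyl, a longer chain such as propyl, bromo or an amine would read at this place on the core of compound 2, and so whether the high number depends on ethyl in particular or the low one on chloro. Also open, from the compounds shown here alone, is whether the same swap on the core of compound 1 would give a step of similar size.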